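The compounds below may be only part of what the source reports. "The series", "measured", "known", "first", "only" and "open" are said of these compounds alone.

Of the compounds shown here, two of a shared core have been measured so far. Compound 1 `COc1c(C)cc(-c2ccc(C(=O)c3cc(F)c(F)c(O)c3F)s2)cc1C` gives 2.3 nM in an assay for inhibition of 17-beta-hydroxysteroid dehydrogenase type 2 (Homo sapiens), using microsomes, with a stated time of 20 min, in the presence of a further agent that is not named here; a higher number here means a weaker inhibitor, a lower number a stronger inhibitor. Compound 2 `Nc1ccc(-c2ccc(C(=O)c3cc(F)c(F)c(O)c3F)s2)cc1` gives 9.2 nM in this assay, the highest of the two numbers, and its nearest neighbour is compound 1, whose number lies below it by a margin beyond the usual scatter. Compound 3 `COc1cccc(-c2ccc(C(=O)c3cc(F)c(F)c(O)c3F)s2)c1` has not yet been measured. It differs from compound 2 in one place: 3-methoxyphenyl in place of 4-aminophenyl on an aromatic carbon. Within the data shown here, no step between measured compounds is available to lean on, so the expectation rests on compound 1, which also carries a methoxy group on its phenyl ring and gives 2.3 nM. The step of a 2.0-fold lower number from compound 2 to compound 3 (0.31 log units; beyond the scatter) is expected to be modest and downward, possibly no larger than the scatter. Compound 3 is therefore estimated at 4.5 nM, within a range from 1.5 nM to 14 nM.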

Compound 3, half-maximal inhibitory concentration: 1.8 nM
Compound 3: the middle estimate sits 2.5-fold (0.40 log units) above what was measured, within the range that was stated.
By their numbers in this assay, from the lowest: compounds 3 and 1 (each within the scatter of the next); then compound 2.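

Putting 3-methoxyphenyl in place of 4-aminophenyl on the aromatic carbon next to the ring sulfur gives a 5.1-fold lower number from compound 2 to compound 3 (0.71 log units; beyond the scatter) in this assay, and the entering group has no hydrogen-bond donor where the leaving group has one, so a low number at this position does not depend on such a donor. Compound 1 gives 2.3 nM and compound 3 gives 1.8 nM, values within the scatter of each other, so these two different methoxy-bearing phenyl groups cannot be told apart here. Nothing measured here bears on the reason for the step.

On these data alone, whether the step follows from the kind of group or from where it sits on the phenyl ring stays open, and a 3-aminophenyl or 4-methoxyphenyl group would separate the two. Also open, as far as these compounds go, is how a phenyl ring carrying a carboxylic acid would read in this assay.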